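A few compounds are considered here, and "the series" means these few. Any claim that something is new, unique, unknown or untested is made for them only; others in the source may bear on it.

Values in a functional assay (mast cells) for inhibition, with Rattus norvegicus as the target; on this read-out higher numbers stand for an effect only at larger amounts of compound and lower numbers for an effect already at smaller amounts:
compound 1 `CC1CC/C(=N\Nc2cccc(Cl)c2)c2ncc(C(=O)O)c(=O)n21`: 311000 nM
compound 2 `CC1CC/C(=N\Nc2ccc(Br)cc2)c2ncc(C(=O)O)c(=O)n21`: 2000 nM
compound 3 `CC1CC/C(=N\Nc2ccccc2O)c2ncc(C(=O)O)c(=O)n21`: 208000 nM

Compound 2 has the lowest of the three numbers, and its steps to both others lie beyond the scatter. Compound 4 `CC(=O)c1ccc(N/N=C2\CCC(C)n3c2ncc(C(=O)O)c3=O)cc1` is not yet measured. It differs from compound 2 by acetyl in place of bromo on an aromatic carbon, para to a large group.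

The measured steps all change the aryl group on the amine nitrogen. Two are large, a 160-fold lower number from compound 1 to compound 2 (2.19 log units; beyond the scatter) and a 100-fold higher number from compound 2 to compound 3 (2.02 log units; beyond the scatter), while a 1.5-fold lower number from compound 1 to compound 3 (0.17 log units; within the scatter) stays within the scatter. Changes here can therefore move the number a long way, but no measured compound carries acetyl, and the direction for this swap is not shown. With only compound 2 at 2000 nM as the anchor, a modest rise is expected, smaller than either large step, and the expected change is a 3.0-fold higher number from compound 2 to compound 4 (0.48 log units; beyond the scatter). Compound 4 is estimated at 6000 nM, with an expected range of 1000 nM to 60000 nM.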

Compound 4, half-maximal effective concentration: 8100 nM
The estimate for compound 4 lay 1.4-fold (0.13 log units) below the measured number, and the stated range covers the measured number.
By their numbers in this assay, from the lowest: compound 2; then compound 4; then compounds 3 and 1 (each within the scatter of the next).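

In this assay, the place para to a large group now holds a second substituent, and acetyl in place of bromo gives a 4.1-fold higher number from compound 2 to compound 4 (0.61 log units; beyond the scatter). For the compounds shown here, three heavy atoms and a hydrogen-bond acceptor thus enter at this place with only a modest shift, and among the four compounds, those substituted here, compound 2 at 2000 nM and compound 4 at 8100 nM, have lower numbers than compounds 1 and 3, with no compound going against this. Nothing available explains the rise from bromo to acetyl.

Still open, going by these compounds, is whether this trend depends on the place or on the particular groups, since bromo appears at no other ring position. An amine or a carboxylic acid at this place, or a longer chain in place of acetyl, would show how far the trend extends.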